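The source may report more compounds than this note shows. Statements on the series, on what has been measured and on what is new or still open speak of the compounds shown alone.

Measured compounds:
compound 1 `COc1ccc(-n2c(SC(C)C(=O)Nc3nc(C)c(Br)cc3Br)nc3ccccc32)cc1` with 9700 nM
compound 2 `COc1ccc(-n2c(SC(C)C(=O)Nc3ncc(C(F)(F)F)cc3Cl)nc3ccccc32)cc1` with 9200 nM
compound 3 `COc1ccc(-n2c(SC(C)C(=O)Nc3nc(C)cs3)nc3ccccc32)cc1` with "not determined" (no result reported)

Within the data shown here, in an ADME assay on Vero cells (Chlorocebus sabaeus) for cytotoxicity, read by MTT assay, with a stated time of 24 h (on this read-out lower numbers stand for higher toxicity in this test and higher numbers for lower toxicity in this test), compound 1 gives 9700 nM and compound 2 gives 9200 nM; the only measured step, a 1.1-fold lower number from compound 1 to compound 2 (0.02 log units; within the scatter), stays within the scatter. Among the measured compounds shown here, compound 3 has no number in this assay, so no measured step starts from it. Compound 4 `COc1ccc(-n2c(SC(C)C(=O)Nc3nc(C)c(Cl)cc3Cl)nc3ccccc32)cc1` differs from compound 3 by 3,5-dichloro-6-methylpyridin-2-yl in place of 4-methyl-1,3-thiazol-2-yl on an amide-type nitrogen. The group that enters resembles the groups carried by compound 1 and compound 2, which sit close to each other in this assay, whereas nothing measured involves the group that leaves. No direction can be argued from the data; compound 4 is therefore expected to land near the values of compound 1 and compound 2, around 9500 nM, with a range from 4000 nM to 25000 nM.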

Compound 4, half-maximal cytotoxic concentration: 7250 nM
Estimate against measurement, compound 4: 1.3-fold (0.12 log units) above, within the range that was stated.
By their numbers in this assay, from the lowest: compounds 4, 2 and 1 (each within the scatter of the next).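

In this assay, the step of a 1.3-fold lower number from compound 1 to compound 4 (0.13 log units; within the scatter) and the step of a 1.3-fold lower number from compound 2 to compound 4 (0.10 log units; within the scatter) both stay within the scatter. Compound 4 thus joins compound 1 and compound 2 as a third substituted pyridin-2-yl group on the amide-type nitrogen, and all three read alike, whether the group carries two chlorines and a methyl, two bromines and a methyl, or a chlorine and a trifluoromethyl. Nothing available explains why these values sit together. Still open, on these data alone, is whether a pyridin-2-yl ring carrying an amine or a carboxylic acid would read the same.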